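Replacing vinyl on the carbonyl of compound 2

This account rests on a few compounds, and the source may have more. Where it says the series, first, only, none or still open, it means among the compounds named here.

Values measured in a functional assay on the whole organism for inhibition, with Cavia porcellus as the target (a lower number here means that less compound is needed, a higher number that more compound is needed for the effect), are these:
- compound 1 `COc1ccccc1OCC1SCCN1C(=O)C[S+](C)[O-]`: 25 mg/kg
- compound 2 `C=CC(=O)N1CCSC1COc1ccccc1OC`: 74 mg/kg

Compound 2 has the higher number of the two, so more of it is needed for the effect. Going to compound 3 `COc1ccccc1OCC1SCCN1C(=O)CC(C)=O` brings the change 2-oxopropyl in place of vinyl on a carbonyl carbon in which 2-oxopropyl stands in place of vinyl on a carbonyl carbon. Among the measured compounds shown here, since compound 3 loses the vinyl that went with a 3.0-fold higher number from compound 1 to compound 2 (0.47 log units; beyond the scatter) in the one measured step bearing on this, a modest move back to a lower number is expected, although its new group differs from that of compound 1. The expected step is a 2.3-fold lower number from compound 2 to compound 3 (0.36 log units; beyond the scatter) and it rests on thin evidence. For compound 3 the estimate is 32 mg/kg with an expected range from 11 mg/kg to 90 mg/kg in this assay once measured.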

Compound 3, dose for half-maximal effect: 30 mg/kg
Estimate against measurement, compound 3: 1.1-fold (0.03 log units) above; the range from low to high includes it.
By their numbers in this assay, from the lowest: compounds 1 and 3 (each within the scatter of the next); then compound 2.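

Replacing vinyl on this carbonyl with 2-oxopropyl gives a 2.5-fold lower number from compound 2 to compound 3 (0.39 log units; beyond the scatter), so a low number does not depend on the particular group in compound 1. The groups of the other pair differ in their atoms on the saturated chain carbon bound to the carbonyl carbon, yet the step is a 1.2-fold higher number from compound 1 to compound 3 (0.08 log units; within the scatter), which shows that the sulfur in that group is not required for the lower number. Nothing shown here explains why either step has its size.

As far as these compounds go, whether an amine, a carboxylic acid or a longer chain on this carbonyl would lower the number further remains open.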